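A few compounds are considered here, and "the series" means these few. Any claim that something is new, unique, unknown or untested is made for them only; others in the source may bear on it.

Measured so far:
compound 1 `CCOC(=O)C(CS)NC(=O)c1cc(C(C)(C)C)c(O)c(C(C)(C)C)c1` — 46%
compound 2 `CC(C)(C)c1cc(/C=C/C(=O)NCCS)cc(C(C)(C)C)c1O` — 60%

In a functional assay, with a stated time of 30 min, tested at 100 uM (on this read-out higher numbers stand for a stronger effect at the one concentration tested and lower numbers for a weaker effect), compound 2 stands highest of the two numbers; compound 1 sits lower, and that gap is beyond the scatter. Among the measured compounds shown here, no step between measured compounds is defined here, so the two values show only that much.

Compound 3 `CCOC(=O)C(CS)NC(=O)/C=C/c1cc(C(C)(C)C)c(O)c(C(C)(C)C)c1` is next to be measured. It differs from compound 2 by ethoxycarbonyl in place of hydrogen on a saturated chain carbon bound to an amide-type nitrogen and a saturated chain carbon. Compound 1, which carries the same ethoxycarbonyl on its chain, gives 46%. On that basis a small downward step, or none beyond the scatter, is expected in this assay, so compound 3 is estimated at 54%, within 40% to 68%. The step expected is a number 6 percentage points lower from compound 2 to compound 3 (within the scatter).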

Compound 3, a percentage reported as activity, at one concentration (the size of the read-out at that concentration, not a potency): 70%
Estimate against measurement, compound 3: 16 percentage points below; measured number above the stated range.
By their numbers in this assay, from the lowest: compound 1; then compounds 2 and 3 (each within the scatter of the next).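

On the saturated chain carbon bound to an amide-type nitrogen and a saturated chain carbon, ethoxycarbonyl in place of hydrogen gives a number 10 percentage points higher from compound 2 to compound 3 (within the scatter) in this assay. This position therefore accepts ethoxycarbonyl, with its 5 heavy atoms, without a step beyond the scatter, and compound 2 and compound 3 cannot be ranked on this read-out. No measurement at hand offers an explanation for this step.

From the compounds shown here alone, whether a carboxylic acid or a primary amide at this carbon would hold the read-out at this level remains open. A longer ester chain at the same carbon is also untested in the compounds shown.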